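The source may hold more compounds than are shown below. What is called first, only, known or untested is meant among the compounds shown, and "the series" means these compounds.

Measured in a functional assay on NCI-H23 cells (Homo sapiens) for antiproliferative activity, read by sulforhodamine B assay; on this read-out higher numbers stand for weaker inhibition of growth and lower numbers for stronger inhibition of growth:
compound 1, `CC1CC(=O)c2s/c(=N/c3ccccc3)oc2C1`: 2720 nM
compound 2, `CC1(C)CC(=O)c2s/c(=N/c3ccc(Cl)cc3)oc2C1`: 11600 nM

Of the two measured compounds, compound 2 gives the higher number in this assay, which on this read-out is the weaker inhibition of growth; compound 1 gives the lower number, and the gap between the two is beyond the usual scatter. Within the data shown here, compound 1 and compound 2 differ in more than one place, so no single structural step connects them, and their two values can only be set side by side.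

Compound 3, `CC1CC(=O)c2s/c(=N/c3ccc(Cl)cc3)oc2C1`, is the compound not yet measured. It differs from compound 2 by hydrogen in place of methyl on a saturated ring carbon. On the saturated ring carbon that carries two methyls in compound 2, one methyl gives way to hydrogen, so that compound 3 carries the same single methyl there as compound 1, while it keeps the chlorine-bearing ring of compound 2. Among the measured compounds shown here, no measured step of this kind exists in the set, so the expectation rests on the two values shown and is correspondingly loose. Compound 3 is expected to give 5000 nM in this assay, with a range from 1500 nM to 16000 nM. This estimate implies a step of a 2.3-fold lower number from compound 2 to compound 3 (0.37 log units; beyond the scatter), expected to go toward stronger inhibition of growth, but not with confidence beyond the scatter.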

Compound 3, concentration for 50% growth inhibition: 13500 nM
The estimate for compound 3 lay 2.7-fold (0.43 log units) below the measured number; the range from low to high includes it.
By their numbers in this assay, from the lowest: compound 1; then compounds 2 and 3 (each within the scatter of the next).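

In this assay, hydrogen in place of methyl on a saturated ring carbon gives a 1.2-fold higher number from compound 2 to compound 3 (0.07 log units; within the scatter), so with the chlorine-bearing ring in place, this carbon tolerates one methyl or two without a difference that can be told from the scatter. Among these compounds, compound 3 also isolates the chlorine as a single change for the first time: chloro in place of hydrogen on an aromatic carbon gives a 5.0-fold higher number from compound 1 to compound 3 (0.70 log units; beyond the scatter), a modest step toward weaker inhibition of growth and the only one of the two new steps that lies beyond the scatter. Nothing else measured here bears on either step, so neither can be explained.

The compounds shown leave open whether the swap of methyl for hydrogen would read the same without the chlorine, and what a second hydrogen, an ethyl group or a hydroxyl group would do on the saturated ring carbon. They also leave open whether the weaker inhibition of growth belongs to chloro in particular or would also appear with fluoro or methoxy on the aromatic carbon.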